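Morpholine in place of thiomorpholine on the methylpyridine amidrazone

This account rests on a few compounds, and the source may have more. Where it says the series, first, only, none or still open, it means among the compounds named here.

Working notes on a small set of pyridine amidrazone thiosemicarbazides tested in a functional assay on MCF7 cells (Homo sapiens) for cytotoxicity, read by MTT assay, with a stated time of 72 h; on this read-out higher numbers stand for weaker inhibition and lower numbers for stronger inhibition. Compound 1 `N/C(=N\NC(=S)N1CCOCC1)c1ccccn1` gives 4700 nM in this assay. Compound 2 `Cc1cccc(/C(N)=N/NC(=S)N2CCSCC2)n1` reaches only the limit of this assay, > 100000 nM, and no number is known for it; the limit is set out as the limit of > 100000 nM in this assay, at which 1 of the 2 values shown sits. Among the compounds with values here, compound 2 therefore stands at the weak end of what has been measured, while compound 1 carries the only finite value.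

Compound 3 `Cc1cccc(/C(N)=N/NC(=S)N2CCOCC2)n1` is not yet measured. It differs from compound 2 in one place: morpholin-4-yl in place of thiomorpholin-4-yl on a thiocarbonyl carbon. Within the data shown here, no measured pair of this series isolates that exchange, so no size can be read off. Compound 1, which also carries the morpholin-4-yl group, gives 4700 nM, but it differs from compound 3 elsewhere as well, so it is only a loose guide.

On that basis compound 3 is expected to move from the limit toward stronger inhibition in this assay, by a step of an at least 3.3-fold lower number from compound 2 to compound 3 (0.52 log units; beyond the scatter). The estimate for compound 3 is 30000 nM, within 6000 nM to 150000 nM.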

Compound 3, half-maximal inhibitory concentration: 21500 nM
Beside the measured number, compound 3's estimate is 1.4-fold (0.14 log units) above it; the range from low to high includes it.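

On a thiocarbonyl carbon, morpholin-4-yl in place of thiomorpholin-4-yl gives the methyl-bearing core its first finite reading in this assay, with an at least 4.6-fold lower number from compound 2 to compound 3 (0.66 log units; beyond the scatter), so the size of this exchange is known only as a lower bound. Compound 2 stands at a limit, and the full size of the step stays unread: the limit of > 100000 nM in this assay, at which 1 of the 3 values shown sits. With morpholin-4-yl held constant, methyl in place of hydrogen on an aromatic carbon can now be sized as well, with a 4.6-fold higher number from compound 1 to compound 3 (0.66 log units; beyond the scatter), so morpholin-4-yl alone does not bring the methyl-bearing core to the level of the core of compound 1.

On these data alone, whether the thiomorpholin-4-yl to morpholin-4-yl exchange has a similar effect on the core without the methyl stays open, as only the methyl-bearing core shows this exchange. Also open, as far as these compounds go, is how other groups would read in this assay, such as piperidin-1-yl or dimethylamino on the thiocarbonyl carbon, or ethyl or chlorine in place of the methyl.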